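Bromo Added to the Nitro Aryl Ether of Compound 1

This account rests on a few compounds, and the source may have more. Where it says the series, first, only, none or still open, it means among the compounds named here.

compound 1 `CN1CCC[C@H]1COc1cccc([N+](=O)[O-])c1` — 946 nM
compound 2 `CN1CCC[C@H]1COc1cccc(C#CCCCCO)c1` — 8300 nM
compound 3 `CN1CCC[C@H]1COc1cc(O)cc(-c2ccc(O)cc2)c1` — 30 nM

In an assay on HEK243 cells for displacement of a labelled ligand from Neuronal acetylcholine receptor; alpha3/beta4 (Homo sapiens), read by scintillation counting, with a stated time of 5 min (a lower number here means a stronger inhibitor, a higher number a weaker inhibitor), compound 1 gives 946 nM, the second highest of the three numbers; compound 3 gives a far lower number at 30 nM, while compound 2 gives a higher one at 8300 nM.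

Compound 4 `CN1CCC[C@H]1COc1cc(Br)cc([N+](=O)[O-])c1` differs from compound 1 as bromo in place of hydrogen on an aromatic carbon. Among the measured compounds shown here, the one single-point step known, an 8.8-fold higher number from compound 1 to compound 2 (0.94 log units; beyond the scatter), exchanges the nitro group itself and does not bear directly on a bromo entering on an aromatic carbon meta to the nitro group. For the measured compounds named here, compound 3, which carries two substituents on the core of compound 1, shows the lowest number, but no single step links it to compound 1. A modest downward step, a 2.1-fold lower number from compound 1 to compound 4 (0.32 log units; beyond the scatter), is expected, with wide uncertainty. Compound 4 is estimated at 450 nM, range 150 nM to 1400 nM.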

Compound 4, inhibition constant: 415 nM
Compound 4: the middle estimate sits 1.1-fold (0.04 log units) above what was measured; the range from low to high includes it.
By their numbers in this assay, from the lowest: compound 3; then compound 4; then compound 1; then compound 2.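

Bromo in place of hydrogen on an aromatic carbon, meta to a nitro group, gives the first single-place change in this series that keeps the nitro group, and the step runs downward: a 2.3-fold lower number from compound 1 to compound 4 (0.36 log units; beyond the scatter). The earlier step, which exchanged the nitro group itself, went the other way, so this position on the core of compound 1 accepts bromo with no loss in the number. Nothing measured here accounts for the step.

The compounds shown leave open whether chloro, methyl or an amine at this position would follow bromo. Also open, going by these compounds, is whether bromo gives the same step when a longer chain stands in place of the nitro group.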